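Changing the aryl group on a triazole-type ring nitrogen

A few compounds are considered here, and "the series" means these few. Any claim that something is new, unique, unknown or untested is made for them only; others in the source may bear on it.

Three close relatives built on one shared core are under discussion here. Compound 1 `COc1ccc(/C=C\C(=O)O)c(OCc2cn(-c3ccc(NC(=O)c4ccccc4)cc3)nn2)c1CC=C(C)C` is the only one with a firm result: in a functional assay on A-431 cells (Homo sapiens) for cytotoxicity, read by MTT assay, with a stated time of 24 h (on this read-out higher numbers stand for weaker inhibition and lower numbers for stronger inhibition), compound 1 gives 21200 nM, which places it among the weak inhibitors of cell growth in this test. For the measured compounds named here, compound 2 `COc1ccc(-n2cc(COc3c(/C=C\C(=O)O)ccc(OC)c3CC=C(C)C)nn2)cc1` was put forward in the same study, yet in this assay compound 2 gives "not determined" (no result reported), so compound 2 stands nowhere on the scale of numbers at present; the only anchor nearby is compound 1 and its weak value.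

Compound 3 `COc1ccc(/C=C\C(=O)O)c(OCc2cn(-c3cccc([N+](=O)[O-])c3)nn2)c1CC=C(C)C` differs from compound 2 in a single spot: 3-nitrophenyl in place of 4-methoxyphenyl on an aromatic nitrogen. With no measured step between any two of these compounds, there is nothing to calibrate the size of this exchange against, and the expectation for this assay is a step of no size beyond the usual scatter, in neither direction, leaving compound 3 close to where compound 1 sits. Compound 3 is therefore expected to give about 20000 nM, estimated to fall somewhere between 7000 nM and 60000 nM, with a fair chance that the assay returns only a limit.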

Compound 3, half-maximal inhibitory concentration: 18400 nM
The estimate for compound 3 lay 1.1-fold (0.04 log units) above the measured number; the measured number falls inside the stated range.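

For the compounds shown here, compound 2 has no number to set beside the result for compound 3, so no step between these two compounds can be read. The compounds shown leave open whether exchanging 4-methoxyphenyl for 3-nitrophenyl on the ring nitrogen changes the read-out at all. No supporting measurement is available to help interpret the result for compound 3.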